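One Stereocentre Left Undrawn, Same Atoms and Bonds

The source may hold more compounds than are shown below. What is called first, only, known or untested is meant among the compounds shown, and "the series" means these compounds.

Two compounds with a shared core, compound 1 `CN(C)CCN(C)c1ccc(C#N)c(CN2CCN(C(c3ccccc3)c3ccc(Cl)cc3)CC2)c1` and compound 2 `CN1CCCN(c2ccc(C#N)c(CN3CCN([C@@H](c4ccccc4)c4ccc(Cl)cc4)CC3)c2)CC1`, have been measured in a toxicity assay on Huh-7.5 cells (Homo sapiens) for cytotoxicity, read by MTT assay, with a stated time of 96 h; a higher number here means that more compound is tolerated, a lower number that less compound is tolerated. In that test, compound 1 gives 5660 nM, a real number that can serve as a reference point.

Compound 2 gives > 20000 nM, which is a limit of the assay and not a number. On these data alone, its exact position therefore stays unknown.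

The next compound, compound 3 `CN1CCCN(c2ccc(C#N)c(CN3CCN(C(c4ccccc4)c4ccc(Cl)cc4)CC3)c2)CC1`, changes very little on paper: the two compounds have the same atoms and bonds; at least one stereo element is drawn with a configuration in one of them and without one in the other: 1 of 1 stereo elements differ; a stereocentre at a saturated chain carbon is drawn S in compound 2 and without a configuration in compound 3. The two compounds have the same atoms and bonds, and the stereocentre at a saturated chain carbon is drawn S in compound 2 and without a configuration in compound 3.

Going by the values given here, no measured pair here shows what such a change does in this assay. The expectation therefore rests on the shared atoms and bonds alone: no movement beyond the scatter, with a slight lean towards less compound being tolerated.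

The expected change is an at least 1.1-fold lower number from compound 2 to compound 3 (0.04 log units; that floor lies within the scatter). For compound 3 the estimated value is 18000 nM, with an expected range of 9000 nM to 36000 nM.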

Compound 3, half-maximal cytotoxic concentration: 7340 nM
Beside the measured number, compound 3's estimate is 2.5-fold (0.39 log units) above it, outside the stated range (below it).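

In this assay, going by these compounds alone, an at least 2.7-fold lower number from compound 2 to compound 3 (0.43 log units; beyond the scatter) is the first sign that the way this saturated chain carbon is drawn goes along with a real shift in how much compound is tolerated, and only one difference separates the pair: the fact that one of compounds 2 and 3 is drawn with a defined configuration and the other without, at the place where they differ. That step has only a floor and no exact size, because compound 2 sits at a limit of the assay and not at a number: the limit of > 20000 nM in this assay, at which 1 of the 3 values shown sits. With the stereocentre drawn without a configuration in both compound 1 and compound 3, the change to 4-methyl-1,4-diazepan-1-yl in place of (2-(dimethylamino)ethyl)(methyl)amino on an aromatic carbon gives a 1.3-fold higher number from compound 1 to compound 3 (0.11 log units; within the scatter) and stays within the scatter.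

The compounds shown leave open where compound 2 truly lies and how the opposite configuration at this carbon, drawn R, would read in this assay. They also leave open whether the same gap between a drawn and an undrawn stereocentre would appear with the (2-(dimethylamino)ethyl)(methyl)amino group of compound 1, or with a carboxylic acid on that aromatic carbon in its place.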